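The source may hold more compounds than are shown below. What is called first, only, known or untested is meant among the compounds shown, and "the series" means these compounds.

Working notes on the series. In a functional assay on A549 cells (Homo sapiens) for antiproliferative activity, read by sulforhodamine B assay, with a stated time of 48 h (on this read-out higher numbers stand for weaker inhibition of growth and lower numbers for stronger inhibition of growth), compound 1 `O=C(/C=C/c1cccc(S(=O)(=O)c2ccc3ccccc3n2)c1)NO` gives 270 nM and compound 2 `COc1ccc2nc(S(=O)(=O)c3cccc(/C=C/C(=O)NO)c3)ccc2c1` gives 350 nM. These two values sit together at the low end of the three measured, and compound 3 `O=C(/C=C/c1cccc(S(=O)(=O)c2ccc3cc(Cl)ccc3n2)c1)NO` gives 1010 nM. Compound 1 therefore stands at the low end of the set, but it is not separated from compound 2.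

The next compound, compound 4 `O=C(/C=C/c1cccc(S(=O)(=O)c2ccc3cccc(F)c3n2)c1)NO`, differs from compound 1 by fluoro in place of hydrogen on an aromatic carbon.

Two measured steps also replace hydrogen on an aromatic carbon. With methoxy the result is a 1.3-fold higher number from compound 1 to compound 2 (0.11 log units; within the scatter), and with chloro it is a 3.7-fold higher number from compound 1 to compound 3 (0.57 log units; beyond the scatter). Going between those two groups gives a 2.9-fold higher number from compound 2 to compound 3 (0.46 log units; beyond the scatter). Within the data shown here, no fluoro compound has been measured, and neither step places its group on the carbon that carries fluoro in compound 4, so these steps are only a loose guide. They point to no drop in this assay, and to a rise no larger than the chloro step, or none beyond the scatter.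

The expected step is a 1.4-fold higher number from compound 1 to compound 4 (0.15 log units; within the scatter). For compound 4 the estimated value is 380 nM, with an expected range of 170 nM to 900 nM.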

Compound 4, concentration for 50% growth inhibition: 640 nM
For compound 4 the middle estimate is 1.7-fold (0.23 log units) below the measured one; low and high end bracket the measured number.
By their numbers in this assay, from the lowest: compounds 1, 2, 4 and 3 (each within the scatter of the next, the first and the last beyond it).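

In this assay, this aromatic carbon, ortho to a fused ring, does not tolerate even a small change without effect: fluoro in place of hydrogen, a single heavy atom, gives a 2.4-fold higher number from compound 1 to compound 4 (0.37 log units; beyond the scatter). Among the replacements of hydrogen in the series, this step joins a 3.7-fold higher number from compound 1 to compound 3 (0.57 log units; beyond the scatter) in moving to a higher number, whereas a 1.3-fold higher number from compound 1 to compound 2 (0.11 log units; within the scatter) does not, although the chloro and methoxy groups sit on a different carbon, so the three steps do not describe one position. No measurement on hand bears on why the number rises at this position with fluoro.

The compounds shown leave open whether the rise belongs to fluoro itself or to any replacement of hydrogen on this carbon, and an amine or a carboxylic acid at the same place would help to separate those two readings. Among these compounds, they also leave open whether fluoro on the carbon that carries chloro in compound 3 would give a step like the one seen for compound 4.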